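This account rests on a few compounds, and the source may have more. Where it says the series, first, only, none or still open, it means among the compounds named here.

The three measured compounds, all tested in a functional assay on A-431 cells (Homo sapiens) for cytotoxicity, read by MTT assay, with a stated time of 72 h, tested at 1 uM; a higher number here means more inhibition of growth at the concentration tested, a lower number less inhibition of growth:

Compound 1, `N/C(=N\NC(=S)N1CCCCC1)c1ccccn1`: 24.4%
Compound 2, `Cc1cccc(/C(N)=N/NC(=S)N2CCCCC2)n1`: 35%
Compound 3, `Cc1cccc(/C(N)=N/NC(=S)N2CCCC2)n1`: 21%

All three share a thiosemicarbazide-type backbone that joins an amidine on a pyridine ring to a thiocarbonyl carrying a cyclic amine. Compound 2 carries a methyl group on the pyridine ring and a piperidin-1-yl on the thiocarbonyl carbon. Two single changes lead away from it. One is hydrogen in place of methyl on an aromatic carbon; this step, a number 10.6 percentage points lower from compound 2 to compound 1 (beyond the scatter), lies beyond the scatter. The other is pyrrolidin-1-yl in place of piperidin-1-yl on a thiocarbonyl carbon; this step, a number 14 percentage points lower from compound 2 to compound 3 (beyond the scatter), also lies beyond the scatter. Compound 1 and compound 3 themselves differ by a gap within the scatter, so no order between them can be claimed.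

Compound 4, `N/C(=N\NC(=S)N1CCCC1)c1ccccn1`, has not been measured. Among the measured compounds shown here, it differs from compound 3 by hydrogen in place of methyl on an aromatic carbon, which is the same change as the one from compound 2 to compound 1, at the same place on the ring. The two cores differ as described above, with pyrrolidin-1-yl rather than piperidin-1-yl on the thiocarbonyl carbon. For the measured compounds named here, since the change was seen only once, the expectation rests on that single step because a number 10.6 percentage points lower from compound 2 to compound 1 (beyond the scatter) is the only measurement of it. Removing the methyl from compound 3 is expected to lower the value by a similar amount, giving an expected step of a number 10 percentage points lower from compound 3 to compound 4 (within the scatter). Compound 4 is therefore estimated at 11% in this assay, most likely between 0% and 24%.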

Compound 4, percent growth inhibition at one concentration: 39.8%
Estimate against measurement, compound 4: 28.8 percentage points below, and the stated range ends below it.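

In this assay, hydrogen in place of methyl on an aromatic carbon now gives a number 18.8 percentage points higher from compound 3 to compound 4 (beyond the scatter), which runs opposite to the earlier step, so the effect of removing the methyl did not carry from one core to the other: the same change on two cores in this assay, a number 10.6 percentage points lower (beyond the scatter) from compound 2 to compound 1 and a number 18.8 percentage points higher (beyond the scatter) from compound 3 to compound 4, 29.4 percentage points apart, beyond the scatter of two such steps

The second change, pyrrolidin-1-yl in place of piperidin-1-yl on the thiocarbonyl carbon, gives a number 15.4 percentage points higher from compound 1 to compound 4 (beyond the scatter), and it too runs opposite to its earlier step on the core that carries the methyl: the same change on two cores in this assay, a number 14 percentage points lower (beyond the scatter) from compound 2 to compound 3 and a number 15.4 percentage points higher (beyond the scatter) from compound 1 to compound 4, 29.4 percentage points apart, beyond the scatter of two such steps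

Among these four compounds, then, neither change has a fixed effect that can simply be added on, since the result of each one depends on the group at the other place; the data do not show why this happens, and with only two cores for each change they give no rule for any further core.

As far as these compounds go, it remains open what an ethyl group or a chlorine atom on that aromatic carbon, or a morpholin-4-yl or azepan-1-yl group on the thiocarbonyl carbon, would give. Also open, from the compounds shown here alone, is whether the same reversal between the two changes would appear with any of those groups.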